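The compounds below may be only part of what the source reports. "The series", "measured", "known", "first", "only" and "open" are said of these compounds alone.

Measured so far:

Compound 1, `CNC(=O)c1cc(Oc2ccc(Nc3nccc(N4CCCC4)n3)cc2)ccn1` — 46.6%
Compound 2, `CN(c1ccc(Oc2ncnc3ccsc23)cc1)c1nccc(N2CCc3ccccc32)n1` — 38.2%

Two compounds have been run in a functional assay on MDA-MB-231 cells (Homo sapiens) for inhibition, read by MTT assay, with a stated time of 72 h, tested at 20 uM; a higher number here means more inhibition at the concentration tested (going by the name of the read-out), a lower number less inhibition. On the two numbers shown, compound 1 stands at the top, but the value of compound 2 falls within the usual scatter of that number, so the two cannot be separated on this evidence. Within the data shown here, compound 2 also differs from compound 1 in several places at once, and no single-change step is available between them, so their two values say only that both sit in the middle of the range.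

The next compound, compound 3, is `CNC(=O)c1cc(Oc2ccc(Nc3nccc(N4CCc5ccccc5C4)n3)cc2)ccn1`. It is derived from compound 1 by one change, (1,2,3,4-tetrahydroisoquinolin-2-yl in place of pyrrolidin-1-yl on an aromatic carbon). Compound 2 carries a different bicyclic amine on its own core and gives a number close to compound 1, which offers no sign that a larger amine at this position moves the read-out far. The account therefore expects a step from compound 1 to compound 3 of a number 3.6 percentage points lower from compound 1 to compound 3 (within the scatter), that is, none beyond the scatter in either direction. The value expected for compound 3 is 43%, with a range from 26% to 60%.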

Compound 3, a percentage reported as inhibition, at one concentration (the size of the read-out at that concentration, not a potency): 41.2%
For compound 3 the middle estimate is 1.8 percentage points above the measured one, and the stated range covers the measured number.
By their numbers in this assay, from the lowest: compounds 2, 3 and 1 (each within the scatter of the next).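

In this assay, among these compounds, the step is a number 5.4 percentage points lower from compound 1 to compound 3 (within the scatter), which gives the first direct reading at this position on the shared core. On an aromatic carbon of this six-membered aromatic ring with 2 nitrogen, pyrrolidin-1-yl with its 5 heavy atoms and 1,2,3,4-tetrahydroisoquinolin-2-yl with its 10 heavy atoms, including a six-membered aromatic ring of carbon only, cannot be told apart on this read-out, something compound 2 could not show since it differs from compound 1 in several places at once. No measurement at hand bears on why these two amines cannot be separated.

Going by these compounds, each number is a single reading at one concentration and not a potency, so any difference in potency between compound 1 and compound 3 remains open. On these data alone, it also remains open whether an open-chain amine such as dimethylamino, or a ring amine with a second hetero atom such as morpholin-4-yl, would give a number beyond the scatter of compound 1 at this place.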